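Acetoxymethyl in place of trifluoroethoxymethyl on the furan side chain

The source may report more compounds than this note shows. Statements on the series, on what has been measured and on what is new or still open speak of the compounds shown alone.

Measured so far:
compound 1 `CCOC(=O)c1c(C)coc1-c1ccc2c(CC)cccc2c1OC` gives 2.2 ug/mL in a functional assay on KB cells (Homo sapiens) for cytotoxicity, read by MTT assay, with a stated time of 72 h; on this read-out higher numbers stand for an effect only at larger amounts of compound and lower numbers for an effect already at smaller amounts;
compound 2 `CCc1cccc2c(OC)c(-c3occ(C)c3COC)ccc12` gives > 10 ug/mL, which is a limit of the assay and not a number;
compound 3 `CCc1cccc2c(OC)c(-c3occ(C)c3COCC(F)(F)F)ccc12` gives 6.6 ug/mL.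

Compound 3 thus stands highest of the two numbers, with compound 1 the nearest (a 3.0-fold higher number from compound 1 to compound 3 (0.48 log units; beyond the scatter)). Compound 4 `CCc1cccc2c(OC)c(-c3occ(C)c3COC(C)=O)ccc12` is its untested neighbour, differing by acetyl in place of 2,2,2-trifluoroethyl on an oxygen on a saturated carbon. Among the measured compounds shown here, two measured steps touch on this change. Replacing ethoxycarbonyl by an ether-bearing chain raised the number, an at least 4.5-fold higher number from compound 1 to compound 2 (0.65 log units; beyond the scatter) and a 3.0-fold higher number from compound 1 to compound 3 (0.48 log units; beyond the scatter), so a group carrying a carbonyl, as compound 1 does, went with the lower number. Adding trifluoromethyl to the ether chain, an at least 1.5-fold lower number from compound 2 to compound 3 (0.18 log units; that floor lies within the scatter), is a step whose floor lies within the scatter. Compound 4 exchanges that fluorinated chain for acetyl, bringing back a carbonyl, so a step in this assay of about a 1.5-fold lower number from compound 3 to compound 4 (0.17 log units; within the scatter) downward is expected, though a step within the scatter remains possible. Compound 4 is therefore estimated at 4.5 ug/mL, within 2 ug/mL to 10 ug/mL.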

Compound 4, concentration for half-maximal effect: > 10 ug/mL
Compound 4: no number, only a limit; the forecaster's own chance of this, stated with the estimate: 20%; middle value at least 2.2-fold (0.34 log units) away from the limit.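

In this assay, compound 4 gives a limit of the assay and not a number. Bringing a carbonyl back on this side chain does not by itself return the lower number of compound 1, since acetoxymethyl in place of ethoxycarbonyl gives an at least 4.5-fold higher number from compound 1 to compound 4 (0.65 log units; beyond the scatter). Acetyl in place of 2,2,2-trifluoroethyl on this oxygen gives an at least 1.5-fold higher number from compound 3 to compound 4 (0.18 log units; that floor lies within the scatter), so this change may be small or larger, and among these side chains only the ethoxycarbonyl of compound 1 and the (2,2,2-trifluoroethoxy)methyl of compound 3 give readable numbers.

The step from compound 2 to compound 4 cannot be read, because both compounds rest on the same limit: the limit of > 10 ug/mL in this assay, at which 2 of the 4 values shown sit. Also open, from the compounds shown here alone, is how a side chain ending in an amine or a carboxylic acid would read in this assay.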